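This account rests on a few compounds, and the source may have more. Where it says the series, first, only, none or still open, it means among the compounds named here.

The measured compounds:
compound 1, `CS(=O)(=O)c1ccc(C2=NN(c3ccc(C(=O)O)cc3)C(c3ccc(Cl)cc3)C2)cc1`: 50.4%
compound 2, `CS(=O)(=O)c1ccc(C2=NN(c3ccc(C(=O)O)cc3)C(c3cccs3)C2)cc1`: 35.6%
compound 3, `CS(=O)(=O)c1ccc(C2=NN(c3ccc(S(N)(=O)=O)cc3)C(c3ccc(Cl)cc3)C2)cc1`: 42.4%

These numbers come from a functional assay on the whole organism for inhibition, with Rattus norvegicus as the target, read by paw edema, with a stated time of 3 h, at a dose of 50 mg/kg by the oral route; on this read-out lower numbers stand for less inhibition and higher numbers for more inhibition at the one dose given (going by the name of the read-out). Compound 3 sits between the other two numbers; its gap to compound 1, a number 8 percentage points lower from compound 1 to compound 3 (within the scatter), is within the scatter, and compound 3 and compound 2 are within the scatter of each other as well, so no real order can be read among these three.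

The step to compound 4, `COc1cc(C2CC(c3ccc(S(C)(=O)=O)cc3)=NN2c2ccc(S(N)(=O)=O)cc2)cc(OC)c1OC`, is 3,4,5-trimethoxyphenyl in place of 4-chlorophenyl on a saturated ring carbon. For the measured compounds named here, one measured step bears on it: the exchange of the group on the same saturated ring carbon, a number 14.8 percentage points lower from compound 1 to compound 2 (beyond the scatter), which moved the number downward by a modest amount. The other measured step, a number 8 percentage points lower from compound 1 to compound 3 (within the scatter), touches a different part of the molecule and stayed within the scatter, so it says nothing about this change. Going by the values given here, only one exchange at that carbon has been seen, and the group entering here is not the one seen there, so the expectation rests on a single comparison and is held loosely. Compound 4 is therefore expected to come out lower, by about a number 9.4 percentage points lower from compound 3 to compound 4 (within the scatter). The estimate for compound 4 in this assay is 33%, with a range from 18% to 48%.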

Compound 4, a percentage reported as inhibition, in the whole organism at one dose (the size of the read-out at that dose, not a potency): 73.7%
Estimate against measurement, compound 4: 40.7 percentage points below; the measured number lies above the stated range.
By their numbers in this assay, from the lowest: compounds 2, 3 and 1 (each within the scatter of the next, the first and the last beyond it); then compound 4.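

In this assay, the saturated ring carbon next to the ring nitrogen proves able to move the number upward as well as downward: 3,4,5-trimethoxyphenyl in place of 4-chlorophenyl gives a number 31.3 percentage points higher from compound 3 to compound 4 (beyond the scatter), whereas thiophen-2-yl in place of 4-chlorophenyl gave a number 14.8 percentage points lower from compound 1 to compound 2 (beyond the scatter). The direction of an exchange at this carbon therefore cannot be carried over from one entering group to another, although these two steps also differ in the group on the other aryl ring, sulfamoyl in one and carboxy in the other. The change brings in more heavy atoms and adds hydrogen-bond acceptors, but nothing measured here connects either difference to the rise in paw edema inhibition.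

The compounds shown leave open whether all three methoxy groups are needed, which a 4-methoxyphenyl or 3,4-dimethoxyphenyl group at the same carbon would help to settle. They also leave open whether 3,4,5-trimethoxyphenyl gives a similar rise when carboxy replaces the sulfamoyl group, and how the effect behaves at other doses.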